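A few compounds are considered here, and "the series" means these few. Any claim that something is new, unique, unknown or untested is made for them only; others in the source may bear on it.

Compound 1 `COc1cc2c(Nc3ccc(C#N)cc3)ncnc2cc1OCCCN(C)Cc1ccccc1` carries a benzyl(methyl)amino group on the chain attached to the shared core. In a functional assay on MCF7 cells (Homo sapiens) for antiproliferative activity, read by MTT assay, with a stated time of 72 h (a lower number here means a stronger inhibitor, a higher number a weaker inhibitor), compound 1 gives > 100000 nM, which is a limit of the assay rather than a measured number. Two related compounds replace that open amine with a ring amine. Compound 2 `COc1cc2c(Nc3ccc(C#N)cc3)ncnc2cc1OCCCN1CCCCC1` gives 35100 nM in this assay, and compound 3 `COc1cc2c(Nc3ccc(C#N)cc3)ncnc2cc1OCCCN1CCC(C)CC1` gives 43100 nM. The two steps, an at least 2.8-fold lower number from compound 1 to compound 2 (0.45 log units; beyond the scatter) and an at least 2.3-fold lower number from compound 1 to compound 3 (0.36 log units; beyond the scatter), both lead to actual numbers. Both start from the limit of > 100000 nM in this assay, at which 1 of the 3 values shown sits, which belongs to compound 1. Between the two ring amines, a 1.2-fold higher number from compound 2 to compound 3 (0.09 log units; within the scatter) shows no difference beyond the scatter. Compound 4 `COc1cc2c(Nc3ccc(C#N)cc3)ncnc2cc1OCCCN1CCC(c2ccccc2)CC1` is not yet measured; its change from compound 1 is 4-phenylpiperidin-1-yl in place of benzyl(methyl)amino on a saturated chain carbon, three bonds along the chain from an oxygen on an aromatic ring. Since it also closes the amine into a ring, as in the steps from compound 1 to compound 2 and compound 3, a comparable lowering is expected, with the step estimated at an at least 3.3-fold lower number from compound 1 to compound 4 (0.52 log units; beyond the scatter). Compound 4 is therefore expected to give about 30000 nM, within a range from 8000 nM to 100000 nM.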

Compound 4, half-maximal inhibitory concentration: 9800 nM
Beside the measured number, compound 4's estimate is 3.1-fold (0.49 log units) above it; the range from low to high includes it.
By their numbers in this assay, from the lowest: compound 4; then compounds 2 and 3 (each within the scatter of the next). At a limit, above all of these: compound 1.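

Among the ring amines, hydrogen and methyl on the saturated ring carbon could not be told apart in this assay, but phenyl there gives a 3.6-fold lower number from compound 2 to compound 4 (0.55 log units; beyond the scatter) and a 4.4-fold lower number from compound 3 to compound 4 (0.64 log units; beyond the scatter), so the group on that carbon now shifts the number beyond the scatter. Compound 1 also carries a six-membered aromatic ring of carbon only, yet moving to 4-phenylpiperidin-1-yl gives an at least 10-fold lower number from compound 1 to compound 4 (1.00 log units; beyond the scatter), so having such a ring is not enough by itself to give a lower number. That step is only a bound, as compound 1 has a limit rather than a measured number: the limit of > 100000 nM in this assay, at which 1 of the 4 values shown sits.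

The compounds shown leave open whether a cyclohexyl or a benzyl group on the same ring carbon would match phenyl. They also leave open how a longer chain carrying 4-phenylpiperidin-1-yl would read.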